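The source may report more compounds than this note shows. Statements on the series, on what has been measured and on what is new or still open speak of the compounds shown alone.

Compound 1 `O=C(O)COc1ccc(-c2coc3cc(OCC(=O)O)ccc3c2=O)cc1` and compound 2 `CCOC(=O)COc1ccc2c(=O)c(-c3ccc(O)cc3)coc2c1` share the same core and differ at both of its oxygen-bearing positions. In an assay (Cricetulus griseus) for inhibition of aldehyde dehydrogenase, mitochondrial (Homo sapiens) (a higher number here means a weaker inhibitor, a lower number a stronger inhibitor), compound 1 gives >> 9000 nM, which is a limit of the assay rather than a number; it sits at the limit of >> 9000 nM in this assay, at which 1 of the 2 values shown sits. In this assay, for the measured compounds named here, compound 2 gives 130 nM, the only actual number among the two measured compounds, so there is no measured step to compare with.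

Compound 3 `C=CCCCCOc1ccc2c(=O)c(-c3ccc(O)cc3)coc2c1` has not yet been measured in this assay. Compared with compound 2, the change is pent-4-en-1-yl in place of ethoxycarbonyl on a saturated chain carbon bound to an oxygen on an aromatic ring. Put another way, an (ethoxycarbonyl)methoxy chain becomes a (hex-5-en-1-yl)oxy chain of the same heavy-atom length, while the free hydroxyl on the other ring is kept, as in compound 2.

Going by the values given here, with no measured step to lean on, the expectation is that the shift from compound 2 to compound 3 stays close to the scatter, with a modest lean toward stronger inhibition, as a 1.9-fold lower number from compound 2 to compound 3 (0.27 log units; within the scatter). Compound 3 is therefore expected to give about 70 nM in this assay, within a range from 15 nM to 350 nM.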

Compound 3, half-maximal inhibitory concentration: 150 nM
Compound 3: middle estimate off by 2.1-fold (0.33 log units), on the low side; measured number inside the range.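

In this assay, putting pent-4-en-1-yl in place of ethoxycarbonyl on a saturated chain carbon bound to an oxygen on an aromatic ring gives a 1.2-fold higher number from compound 2 to compound 3 (0.06 log units; within the scatter). For the compounds shown here, this is the first measured step at this position, and it shows that the two groups cannot be told apart here: ethoxycarbonyl, with its 2 hydrogen-bond acceptors, gives way to an all-carbon group with 0, and the number stays within the scatter, so in this pair those acceptors are not needed to keep the value. Nothing measured here offers a reason for this outcome.

Compound 1 gives >> 9000 nM in this assay, which is a limit of the assay and not a number, and since it differs from compound 2 in two places, the data cannot say which of those places accounts for it. Also open, on these data alone, is whether an amine at the end of this chain, or a much longer chain, would hold the value as well as these two groups do.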